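Bromo on the Phenyl of Compound 3: Expected Cytotoxicity

The compounds below may be only part of what the source reports. "The series", "measured", "known", "first", "only" and "open" are said of these compounds alone.

Measured so far:
- Compound 1, `CCOC(=O)c1c(-c2c(Cl)c3ccccc3oc2=O)nn(-c2ccccc2)c1C(=O)OCC`: 34000 nM
- Compound 2, `CCOC(=O)c1c(-c2c(Cl)c3cc(C)ccc3oc2=O)nn(-c2cccc(Cl)c2)c1C(=O)OCC`: 128000 nM
- Compound 3, `CCOC(=O)c1c(-c2cc3ccccc3oc2=O)nn(-c2ccccc2)c1C(=O)OCC`: 100000 nM

All three were tested in a functional assay on A549 cells (Homo sapiens) for cytotoxicity, read by MTT assay, with a stated time of 48 h; a higher number here means a weaker inhibitor, a lower number a stronger inhibitor. Among these numbers compound 3 stands second highest; compound 2 sits a step away that is within the scatter, while compound 1 gives the lowest number, the step from compound 1 to compound 3 being a 2.9-fold higher number from compound 1 to compound 3 (0.47 log units; beyond the scatter).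

Compound 4, `CCOC(=O)c1c(-c2cc3ccccc3oc2=O)nn(-c2ccc(Br)cc2)c1C(=O)OCC`, differs from compound 3 by bromo in place of hydrogen on an aromatic carbon. No measured step touches that phenyl alone: the only step shown, a 2.9-fold higher number from compound 1 to compound 3 (0.47 log units; beyond the scatter), changes the shared core, not the phenyl. Compound 2 carries a chloro on its phenyl but also a methyl on the core, so its value against compound 1 cannot be split between the two changes. With nothing directly bearing on the change, no step beyond the scatter is expected, with the estimated step being a 1.1-fold higher number from compound 3 to compound 4 (0.04 log units; within the scatter). Compound 4 is therefore expected to give about 110000 nM, with a range from 45000 nM to 280000 nM.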

Compound 4, half-maximal inhibitory concentration: 100000 nM
For compound 4 the middle estimate is 1.1-fold (0.04 log units) above the measured one; measured number inside the range.
By their numbers in this assay, from the lowest: compound 1; then compounds 3, 4 and 2 (each within the scatter of the next).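

Going by these compounds alone, until now, no pair of compounds isolated the phenyl. Compound 2 changes its phenyl and its core together. Compounds 3 and 4 provide that reading: in this assay, going from phenyl to 4-bromophenyl gives no change at the digits printed from compound 3 to compound 4 (within the scatter), so this bromo, para to a large group, leaves no measurable mark on this compound. Within the data shown here, the only step beyond the scatter still belongs to the chloro on the core, at a 2.9-fold higher number from compound 1 to compound 3 (0.47 log units; beyond the scatter), and nothing available explains why the bromo step reads as it does.

An amine or a carboxylic acid at the same place on the phenyl might read differently, so this result cannot be extended to all groups there. On these data alone, it also remains open whether bromo would read the same on the chloro-bearing core of compound 1.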